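Compound 3: a new group on the chain carbon

A few compounds are considered here, and "the series" means these few. Any claim that something is new, unique, unknown or untested is made for them only; others in the source may bear on it.

Compound 1 `Nc1ncnc2c1c(-c1ccc(Oc3ccccc3)cc1)nn2Cc1cccc(NC(=O)CCl)c1`: 400 nM
Compound 2 `Nc1ncnc2c1c(-c1ccc(Oc3ccccc3)cc1)nn2Cc1ccccc1F`: 34300 nM

In a functional assay on Maver1 cells (Homo sapiens) for antiproliferative activity, read by luminescence, with a stated time of 72 h (on this read-out lower numbers stand for stronger inhibition and higher numbers for weaker inhibition), compound 2 has the higher of the two numbers at 34300 nM, making it the weaker of the pair. Compound 3 `Nc1cccc(Cn2nc(-c3ccc(Oc4ccccc4)cc3)c3c(N)ncnc32)c1` differs from compound 2 in one place: 3-aminophenyl in place of 2-fluorophenyl on a saturated chain carbon bound to an aromatic nitrogen. In words, this puts 3-aminophenyl in place of 2-fluorophenyl on a saturated chain carbon bound to an aromatic nitrogen.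

Among the measured compounds shown here, only one measured step bears on this change: an 86-fold higher number from compound 1 to compound 2 (1.93 log units; beyond the scatter). It is large, beyond the scatter, and lies at the same place. The 3-aminophenyl group of compound 3 resembles the group in compound 1 but lacks its chloromethyl carbonyl part. A smaller step towards lower numbers is therefore expected, recovering only part of that gap.

The estimated change is a 2.9-fold lower number from compound 2 to compound 3 (0.46 log units; beyond the scatter).

Compound 3 is expected at 12000 nM, with an estimated range of 3000 nM to 40000 nM.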

Compound 3, half-maximal inhibitory concentration: 16800 nM
For compound 3 the middle estimate is 1.4-fold (0.15 log units) below the measured one; the measured number falls inside the stated range.
By their numbers in this assay, from the lowest: compound 1; then compound 3; then compound 2.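

In this assay, replacing 2-fluorophenyl with 3-aminophenyl on the chain carbon gives only a modest gain, a 2.0-fold lower number from compound 2 to compound 3 (0.31 log units; beyond the scatter). Removing the (chloromethyl)carbonyl from the nitrogen costs far more, a 42-fold higher number from compound 1 to compound 3 (1.62 log units; beyond the scatter), so most of the gap between compound 1 and compound 2 goes with that group and not with the 3-aminophenyl ring that carries it. No supporting measurement is available to explain why that group matters so much.

The compounds shown leave open whether the low number of compound 1 depends on the chlorine or on the carbonyl, which an acetyl group on the same nitrogen would separate. They also leave open how much of the modest step comes from the amine itself, which 3-fluorophenyl or plain phenyl would help to show.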